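The source may hold more compounds than are shown below. What is called first, only, known or untested is meant among the compounds shown, and "the series" means these compounds.

Compound 1, `CNC(=O)[C@@]12C[C@@H]1[C@@H](n1cnc3c(NC)nc(C#Cc4ccc(Cl)cc4)nc31)[C@H](O)[C@@H]2O`, gives 13% in an assay on CHO cells for displacement of a labelled ligand from adenosine receptor A1 (Homo sapiens), read by scintillation counting, with a stated time of 60 min, tested at 10 uM; a higher number here means more inhibition at the concentration tested (going by the name of the read-out), a lower number less inhibition.
Compound 2, `CNC(=O)[C@@]12C[C@@H]1[C@@H](n1cnc3c(NC)nc(C#Cc4cccnc4)nc31)[C@H](O)[C@@H]2O`, gives 16% in this assay.
Compound 3, `CCc1ccc(C#Cc2nc(NC)c3ncn([C@H]4[C@H](O)[C@H](O)[C@]5(C(=O)NC)C[C@H]45)c3n2)o1`, gives 18% in this assay.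

The three numbers sit close together. Compound 2 lies between the other two: its nearest neighbour is compound 3, a number 2 percentage points higher from compound 2 to compound 3 (within the scatter), and its furthest is compound 1, a number 3 percentage points higher from compound 1 to compound 2 (within the scatter), so none of the three can be told apart from another.

Compound 4, `CNC(=O)[C@@]12C[C@@H]1[C@@H](n1cnc3c(NC)nc(C#CC4CC4)nc31)[C@H](O)[C@@H]2O`, has not yet been measured. It differs from compound 2 in one place: cyclopropyl in place of pyridin-3-yl on a triple-bonded carbon.

Every measured step changes the same group on the same triple-bonded carbon. From compound 1 to compound 2 the step is a number 3 percentage points higher from compound 1 to compound 2 (within the scatter), from compound 1 to compound 3 it is a number 5 percentage points higher from compound 1 to compound 3 (within the scatter), and from compound 2 to compound 3 it is a number 2 percentage points higher from compound 2 to compound 3 (within the scatter); all three stay within the scatter. Those steps swap one ring for another of six or five members; none of them brings in a three-membered non-aromatic ring of carbon only, so the change to compound 4 is not directly covered. Going by the values given here, with no measured step on this carbon beyond the scatter, the step to compound 4 is expected to be small, a number 1 percentage points lower from compound 2 to compound 4 (within the scatter), with no clear direction.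

Compound 4 is therefore estimated at 15% in this assay, within a range of 4% to 27%.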

Compound 4, a percentage reported as inhibition, at one concentration (the size of the read-out at that concentration, not a potency): 38%
Compound 4: the middle estimate sits 23 percentage points below what was measured, outside the stated range (above it).
By their numbers in this assay, from the lowest: compounds 1, 2 and 3 (each within the scatter of the next); then compound 4.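

Before compound 4, nothing suggested that this position could shift the read-out in this assay, yet cyclopropyl on the triple-bonded carbon gives a number 22 percentage points higher from compound 2 to compound 4 (beyond the scatter) and, set against the other two aromatic groups, a number 20 percentage points higher from compound 3 to compound 4 (beyond the scatter) and a number 25 percentage points higher from compound 1 to compound 4 (beyond the scatter) as well. Compound 4 is thus the only one of the four that stands clear of the others, so the flat picture held for the three aromatic rings of six or five members and not for the position as a whole. Cyclopropyl differs from those rings both in being non-aromatic and in having fewer heavy atoms, a single compound cannot separate the two, and nothing available explains the rise.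

On these data alone, it remains open whether the rise belongs to the three-membered ring itself or would extend to other small non-aromatic groups on this carbon, such as cyclobutyl, a propyl chain or a short chain ending in an amine. Also open is what potency lies behind these readings, each taken at one concentration.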